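The source may hold more compounds than are shown below. What is called first, only, known or untested is meant among the compounds shown, and "the series" means these compounds.

Compound 1 `O=C(NCc1ccccc1)c1nc(Cc2ccccc2C(F)(F)F)[nH]c(=O)c1O`: > 100000 nM, a limit
Compound 2 `Cn1c(Cc2ccccc2C(F)(F)F)nc(C(=O)NCc2cccnc2)c(O)c1=O`: > 100000 nM, a limit

Both entries come from an ADME assay on HepG2 cells (Homo sapiens) for cytotoxicity, in the presence of a further agent that is not named here (a lower number here means a stronger inhibitor, a higher number a weaker inhibitor), and neither is an exact number. Compound 2 has only a limit in this test, > 100000 nM. It is not alone in this, since the two measured compounds stand together at the limit of > 100000 nM in this assay, at which 2 of the 2 values shown sit.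

Compound 3 `CN(Cc1ccccc1)C(=O)c1nc(Cc2ccccc2C(F)(F)F)n(C)c(=O)c1O` has not yet been measured. It keeps the core of compound 2 and differs in one place: benzyl(methyl)amino in place of ((pyridin-3-yl)methyl)amino on a carbonyl carbon. In words, benzyl(methyl)amino stands in place of ((pyridin-3-yl)methyl)amino on a carbonyl carbon.

Within the data shown here, no measured pair of compounds differing in one place is available as a guide. The expectation therefore rests on the two compounds already at the limit of > 100000 nM in this assay, at which 2 of the 2 values shown sit, and two limits give no measure of how much such a change can do. The expected step, a number no higher from compound 2 to compound 3 (the limit leaves the size open), is none beyond the usual scatter, and another limit is the likeliest report. For compound 3 the estimated value is 100000 nM, with an expected range of 40000 nM to 200000 nM.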

Compound 3, half-maximal inhibitory concentration: > 100000 nM
Compound 3 ended at the assay's limit; the forecaster's own chance of this, stated with the estimate: 80%; the middle value lies on the limit itself.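

Among these compounds, compound 2 and compound 3 both end at a limit in this assay rather than at an exact number, so no step between them can be read: the limit of > 100000 nM in this assay, at which 3 of the 3 values shown sit.

The compounds shown leave open how far each lies from that limit, and whether benzyl(methyl)amino in place of ((pyridin-3-yl)methyl)amino changes the result in this assay at all.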